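Swapping the N-aryl group on compound 2

The source may hold more compounds than are shown below. What is called first, only, known or untested is meant among the compounds shown, and "the series" means these compounds.

compound 1 `COc1ccc(F)cc1N1C(=O)CSC1c1cccc(C(=O)NCCCCn2cccn2)c1` gives 97.3 nM
compound 2 `COc1ccc(F)cc1N1C(=O)CSC1c1cccc(C(=O)NCCCCc2ccccc2)c1` gives 8.8 nM
compound 3 `C#Cc1cc(C(=O)NCCCCc2ccccc2)cc(C2SCC(=O)N2c2ccccc2OC)c1` gives 40.8 nM

In a functional assay on HOS-TE85 cells (Homo sapiens) for inhibition, read by CCK-8 assay, with a stated time of 72 h (a lower number here means a stronger inhibitor, a higher number a weaker inhibitor), compound 2 has the lowest number of the three, with compound 3 (40.8 nM) and compound 1 (97.3 nM) both clearly higher. Compound 4 `O=C(NCCCCc1ccccc1)c1cccc(C2SCC(=O)N2c2ccc(-c3ccccc3)cc2)c1` has not yet been measured. It differs from compound 2 in one place, with 4-phenylphenyl in place of 5-fluoro-2-methoxyphenyl on an amide-type nitrogen in a ring. Among the compounds with values here, no measured step changes this group alone, and compound 3 differs from compound 2 in more than one place. Within the data shown here, the one measured step, an 11-fold lower number from compound 1 to compound 2 (1.04 log units; beyond the scatter), lies on the chain and not on this nitrogen. It shows how far a single change can move the number in this set, so a sizeable step is expected here, though with little certainty. With compound 2 (8.8 nM) lowest of the three, that step is expected to go towards a higher number. The expected size is a 6.8-fold higher number from compound 2 to compound 4 (0.83 log units; beyond the scatter). For compound 4 the estimated value is 60 nM, with an expected range from 12 nM to 300 nM.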

Compound 4, half-maximal inhibitory concentration: > 1000 nM
Compound 4: only a limit was reported; the forecaster's own chance of this, stated with the estimate: 3%; middle value at least 16-fold (1.22 log units) away from the limit.
By their numbers in this assay, from the lowest: compound 2; then compound 3; then compound 1. At a limit, above all of these: compound 4.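

Within the data shown here, until this point, the only single change with a measured step lay on the chain, so compound 4 is the first to show that the amide-type nitrogen in the ring is also highly sensitive to change in this assay. Putting 4-phenylphenyl in place of 5-fluoro-2-methoxyphenyl there gives an at least 110-fold higher number from compound 2 to compound 4 (2.05 log units; beyond the scatter), a large step in the direction of weaker inhibition. The reading for compound 4 is a limit and not a number: the limit of > 1000 nM in this assay, at which 1 of the 4 values shown sits.

This swap removes the methoxy group and the fluorine and also adds a further six-membered aromatic ring, and the compounds shown do not separate these changes. As far as these compounds go, it remains open whether a plain phenyl or a pyridine ring on this nitrogen would keep the number low.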